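Swapping a methoxy for a chloro on compound 1

The source may report more compounds than this note shows. Statements on the series, on what has been measured and on what is new or still open speak of the compounds shown alone.

Of the compounds shown here, three of a shared core have been measured in a functional assay on MV4-11 cells (Homo sapiens) for antiproliferative activity, read by resazurin assay, with a stated time of 72 h; on this read-out higher numbers stand for weaker inhibition and lower numbers for stronger inhibition. Compound 1 `COc1ccc(-c2nc3c(c(-c4ccccc4)nn3-c3ccccc3)c(-c3ccc(O)cc3)c2C#N)cc1` gives 1600 nM, the lowest of the three numbers. Compound 2 `COc1cc(-c2c(C#N)c(-c3ccco3)nc3c2c(-c2ccccc2)nn3-c2ccccc2)ccc1O` gives 35300 nM, and compound 3 `COc1cc(-c2c(C#N)c(-c3cccs3)nc3c2c(-c2ccccc2)nn3-c2ccccc2)ccc1O` gives 44200 nM. Among the measured compounds shown here, the only single-point step among them, a 1.3-fold higher number from compound 2 to compound 3 (0.10 log units; within the scatter), concerns the five-membered aromatic ring and is of no help for the change at hand. Compound 4 `N#Cc1c(-c2ccc(Cl)cc2)nc2c(c(-c3ccccc3)nn2-c2ccccc2)c1-c1ccc(O)cc1` differs from compound 1 by chloro in place of methoxy on an aromatic carbon; the same difference, cut one bond further out, reads 4-methoxyphenyl to 4-chlorophenyl. For the measured compounds named here, no measured pair reports this exchange, so the expectation rests on compound 1 alone. The step from compound 1 to compound 4 in this assay is therefore expected to stay within the scatter, no change at the digits printed from compound 1 to compound 4 (within the scatter), with no direction favoured. Compound 4 is accordingly estimated at 1600 nM, within a range from 500 nM to 5000 nM.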

Compound 4, half-maximal inhibitory concentration: 25100 nM
For compound 4 the middle estimate is 16-fold (1.20 log units) below the measured one; the measured number lies above the stated range.
By their numbers in this assay, from the lowest: compound 1; then compounds 4, 2 and 3 (each within the scatter of the next).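

In this assay, the exchange of 4-methoxyphenyl for 4-chlorophenyl gives a 16-fold higher number from compound 1 to compound 4 (1.20 log units; beyond the scatter) and so is a large step, beyond the scatter. Among the compounds shown here, the only earlier step concerned the five-membered aromatic ring and stayed within the scatter, so this is the first sign that the shared core responds clearly to a single substituent change, here at a place para to a large group. The change swaps methoxy, with two heavy atoms and one hydrogen-bond acceptor, for chloro, with one heavy atom and none, but nothing available explains the step.

As far as these compounds go, with only these two groups at this place, it remains open whether methoxy is favoured in particular or chloro is disfavoured. A fluoro, an ethoxy or a dimethylamino group there could show which of compound 1 and compound 4 sets the pattern.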